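The source may hold more compounds than are shown below. What is called first, only, known or untested is meant among the compounds shown, and "the series" means these compounds.

The measured compounds:
compound 1 `Cc1ccccc1-n1cc(-c2ccccc2)c(-c2ccc3c(c2)NC(=O)CO3)n1` gives 92.2% in a functional assay on DLD-1 cells (Homo sapiens) for cytotoxicity, read by colorimetric assay and MTT assay, with a stated time of 3 days, tested at 1 uM; a higher number here means a weaker effect of the compound at the concentration tested, a lower number a stronger effect
compound 2 `O=C1COc2ccc(-c3nn(-c4ccc(Br)cc4)cc3-c3ccccc3)cc2N1` gives 66.4% in this assay
compound 3 `O=C1COc2ccc(-c3[nH]c(-c4ccccc4)nc3-c3ccccc3)cc2N1` gives 98.2% in this assay

Compound 3 stands highest of the three numbers; compound 1 lies within the scatter of it, while compound 2 lies beyond the scatter below it. Compound 4 `O=C1COc2ccc(-c3[nH]c(-c4ccc(F)cc4)nc3-c3ccccc3)cc2N1` has not yet been measured. It differs from compound 3 by a single change: fluoro in place of hydrogen on an aromatic carbon. Among the compounds with values here, only one measured step exists, a number 25.8 percentage points lower from compound 1 to compound 2 (beyond the scatter), and it concerns a different pair of groups on an aromatic nitrogen in a different core, so it bears on the present change only loosely. Compound 3 and compound 1 show that two different aryl substituents at the same region leave the number within the scatter of each other. A step of no size beyond the scatter, perhaps slightly downward, is therefore expected in this assay for compound 4, namely a number 8.2 percentage points lower from compound 3 to compound 4 (within the scatter). The value of compound 4 is estimated at 90%, with a range from 70% to 102%.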

Compound 4, a percentage reported as activity, at one concentration (the size of the read-out at that concentration, not a potency): 94.8%
Compound 4: the middle estimate sits 4.8 percentage points below what was measured; low and high end bracket the measured number.
By their numbers in this assay, from the lowest: compound 2; then compounds 1, 4 and 3 (each within the scatter of the next).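

In this assay, fluoro in place of hydrogen on an aromatic carbon, para to a large group, gives a number 3.4 percentage points lower from compound 3 to compound 4 (within the scatter), so within the scatter this phenyl to 4-fluorophenyl change leaves the read-out of the core of compound 3 unmoved at this concentration. This is the only step shown on this phenyl ring, and it shows that this carbon can carry a single fluoro with no change beyond the scatter, whereas a number 25.8 percentage points lower from compound 1 to compound 2 (beyond the scatter) concerns a group on an aromatic nitrogen in another core. Nothing measured alongside these numbers speaks to why the fluoro leaves the number in place.

On these data alone, whether a larger group at this carbon, such as bromo, methoxy, an amine or a carboxylic acid, would move the number remains open. As far as these compounds go, it is also open whether the core of compound 3 could reach the number that compound 2 gives, 66.4%.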